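The source may report more compounds than this note shows. Statements on the series, on what has been measured and on what is new or still open speak of the compounds shown alone.

Measured in a functional assay on CWR22R cells (Homo sapiens) for antiproliferative activity, read by propidium iodide staining, with a stated time of 96 h; on this read-out higher numbers stand for weaker inhibition and lower numbers for stronger inhibition:
Compound 1 `CC(O)(COc1cccc(C(F)(F)F)c1)C(=O)Nc1cccc(S(F)(F)(F)(F)F)c1`: 28900 nM
Compound 2 `CC(O)(COc1cc(C(F)(F)F)cc(C(F)(F)F)c1)C(=O)Nc1cccc(S(F)(F)(F)(F)F)c1`: 6500 nM
Compound 3 `CC(O)(CS(=O)(=O)c1ccc(OC(F)(F)F)cc1)C(=O)Nc1ccc(S(F)(F)(F)(F)F)cc1`: 51900 nM

Among these three, compound 2 gives the lowest number, and its gaps to both others lie beyond the scatter. Compound 1 stands nearest to it and compound 3 furthest away. The next candidate is compound 4 `CC(O)(COc1cc(C(F)(F)F)cc(C(F)(F)F)c1)C(=O)Nc1cccc(C(F)(F)C(F)(F)F)c1`, which departs from compound 2 in a single place. The change is a group of 7 heavy atoms (2 carbon, 5 fluorine; no ring) in place of a group of 6 heavy atoms (5 fluorine, 1 sulfur; no ring), on an aromatic carbon: 1,1,2,2,2-pentafluoroethyl enters on an aromatic carbon of a six-membered aromatic ring of carbon only, meta to a large group.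

Among the measured compounds shown here, only one measured step connects compounds that differ in one place: a 4.4-fold lower number from compound 1 to compound 2 (0.65 log units; beyond the scatter). That modest step comes from trifluoromethyl in place of hydrogen on an aromatic carbon, which is a different exchange from the one at issue here. It therefore gives no direct guide to the size or direction of this change. For the measured compounds named here, no measured pair tests the exchange itself, so no shift beyond the scatter in this assay is expected in either direction, although the uncertainty is wide. The expected step is no change at the digits printed from compound 2 to compound 4 (within the scatter). For compound 4, the estimated value is 6500 nM, with an expected range from 2500 nM to 17000 nM.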

Compound 4, half-maximal inhibitory concentration: 4500 nM
Beside the measured number, compound 4's estimate is 1.4-fold (0.16 log units) above it; the measured number falls inside the stated range.
By their numbers in this assay, from the lowest: compounds 4 and 2 (each within the scatter of the next); then compounds 1 and 3 (each within the scatter of the next).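

In this assay, putting 1,1,2,2,2-pentafluoroethyl in place of the group of 6 heavy atoms (5 fluorine, 1 sulfur) on the aromatic carbon gives a 1.4-fold lower number from compound 2 to compound 4 (0.16 log units; within the scatter) and so does not separate the two groups in this setting. Among the compounds shown here, this is the first view of that aromatic carbon, as the earlier step, a 4.4-fold lower number from compound 1 to compound 2 (0.65 log units; beyond the scatter), came from adding trifluoromethyl at the other end of the molecule and said nothing about this place. The result therefore shows that, with the rest of compound 2 held fixed, this exchange leaves the read-out within the usual scatter, although nothing available here accounts for that outcome.

The compounds shown leave open whether a nitrile, an amine or a carboxylic acid on this aromatic carbon would also keep the number in the same range, or whether a longer chain such as heptafluoropropyl would do so. For the compounds shown here, they also leave open whether the two groups would stay equally close with the single trifluoromethyl of compound 1 in place of the two carried by compound 2.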